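The source may report more compounds than this note shows. Statements on the series, on what has been measured and on what is new or still open speak of the compounds shown alone.

Working notes on the series.

Among the compounds with values here, compound 2 `CC(C)(C)c1cc(NC(=O)[C@@H]2CCCCN2C(=O)C2CCOCC2)no1` holds the highest of the two numbers so far in a physicochemical assay for solubility, read by HPLC, at pH 6.8; on this read-out higher numbers stand for higher solubility and lower numbers for lower solubility: compound 2 gives 48 ug/mL. Its nearest neighbour is compound 1 `CC(C)(C)c1cc(NC(=O)[C@@H]2CCCCN2C2CC2)no1`, which in this assay gives 38 ug/mL; the step of a 1.3-fold higher number from compound 1 to compound 2 (0.10 log units; within the scatter) replaces cyclopropyl with (oxan-4-yl)carbonyl on the amine nitrogen in the ring, and it is within the scatter.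

Compound 3 `CC(C)(C)c1cc(NC(=O)[C@@H]2CCCCN2C(=O)N2CCSCC2)no1` has not yet been measured. It differs from compound 2 by thiomorpholin-4-yl in place of oxan-4-yl on a carbonyl carbon; cut one bond further out, the change reads (oxan-4-yl)carbonyl to (thiomorpholin-4-yl)carbonyl. Within the data shown here, the one measured step, from compound 1 to compound 2, touched the same position but exchanged different groups, so it bears only loosely on this change, and it was small. Among the measured compounds shown here, there is no measured pair in which an oxygen in a six-membered ring gives way to a sulfur and a nitrogen.

On that basis the step of a 1.1-fold lower number from compound 2 to compound 3 (0.06 log units; within the scatter) is expected to stay within the scatter, with no direction that the data support. For compound 3 the estimated value in this assay is 42 ug/mL, with a range from 15 ug/mL to 110 ug/mL.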

Compound 3, solubility: 46 ug/mL
Beside the measured number, compound 3's estimate is 1.1-fold (0.04 log units) below it, and the stated range covers the measured number.
By their numbers in this assay, from the lowest: compounds 1, 3 and 2 (each within the scatter of the next).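

Replacing oxan-4-yl with thiomorpholin-4-yl on a carbonyl carbon gives a 1.0-fold lower number from compound 2 to compound 3 (0.02 log units; within the scatter) in this assay, so at this place a six-membered non-aromatic ring with 2 hetero atoms cannot be told apart from one with 1 hetero atom. On the amine nitrogen in the ring, (thiomorpholin-4-yl)carbonyl in place of cyclopropyl gives a 1.2-fold higher number from compound 1 to compound 3 (0.08 log units; within the scatter), and together with a 1.3-fold higher number from compound 1 to compound 2 (0.10 log units; within the scatter) this leaves all three compounds within the scatter of one another, so three different groups at this position have yet to produce a separable difference. No accompanying measurement bears on these numbers, and no cause can be assigned to them.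

The compounds shown leave open whether a group of another kind at this position, such as an open-chain amine or a carboxylic acid, would carry the number beyond the scatter. They also leave open what the sulfur and the nitrogen of the thiomorpholin-4-yl ring each contribute, a question that a morpholine on the same carbonyl carbon would help to separate.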